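Swapping a dihydroxyphenyl for pyridine in a hydrazone series

A few compounds are considered here, and "the series" means these few. Any claim that something is new, unique, unknown or untested is made for them only; others in the source may bear on it.

Four hydrazones share one core and differ only in the aromatic group on the carbon with a double bond to nitrogen. In a functional assay on PC-3 cells (Homo sapiens) for inhibition (a higher number here means a weaker inhibitor, a lower number a stronger inhibitor), compound 1 `Cc1c(C(=O)N/N=C\c2ccc(C(F)(F)F)cc2)oc2cccc(O)c12` reaches only the limit >= 40000 nM. Compound 2 `Cc1c(C(=O)N/N=C\c2cccc(F)c2)oc2cccc(O)c12` likewise stops at the limit >= 40000 nM. Among the compounds with values here, compound 3 `Cc1c(C(=O)N/N=C\c2cccc(O)c2O)oc2cccc(O)c12` gives 12200 nM, the only actual number among the three, as the other two sit at the limit of >= 40000 nM in this assay, at which 2 of the 3 values shown sit. Compound 4 `Cc1c(C(=O)N/N=C\c2cccnc2)oc2cccc(O)c12` carries the change (pyridin-3-yl in place of 2,3-dihydroxyphenyl on a carbon with a double bond to nitrogen). Within the data shown here, the only step that bears on it is an at least 3.2-fold lower number from compound 2 to compound 3 (0.51 log units; beyond the scatter), which ran toward the hydroxyl groups. Removing them is expected to run back, by about a 2.9-fold higher number from compound 3 to compound 4 (0.46 log units; beyond the scatter). Compound 4 is therefore estimated at 35000 nM, with a range from 12000 nM to 80000 nM, and a fair chance that only a limit is reported.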

Compound 4, half-maximal inhibitory concentration: >= 40000 nM
Compound 4 ended at the assay's limit (the forecaster's own chance of this, stated with the estimate: 60%); at least 1.1-fold (0.05 log units) between middle value and limit.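

In this assay pyridin-3-yl in place of 2,3-dihydroxyphenyl gives an at least 3.2-fold higher number from compound 3 to compound 4 (0.51 log units; beyond the scatter) and so, at this position, a ring nitrogen does not keep what the two hydroxyl groups gave. Within the data shown here, compound 3 remains the only compound with an actual number, while three different groups without hydroxyl groups all end at one limit: the limit of >= 40000 nM in this assay, at which 3 of the 4 values shown sit. The step between compound 2 and compound 4 cannot be read, as both values are limits. Still open, from the compounds shown here alone, is whether both hydroxyl groups are needed, which a phenyl ring with a single hydroxyl group would test. Going by these compounds, whether an amine could take their place is also open.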